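The source may report more compounds than this note shows. Statements on the series, on what has been measured and on what is new or still open speak of the compounds shown alone.

Within the data shown here, in a physicochemical assay for lipophilicity (a higher number here means a more lipophilic compound, a lower number a more polar compound), compound 2 `C[C@H]1CC[C@@H]2[C@@H](OC(=O)[C@]23CC(c2c(Cl)cccc2Cl)N(c2ccccc2)O3)[C@]2(C)C(=O)C=C[C@@]12O` gives 4.45, the higher of the two numbers measured so far, while compound 1 `C[C@H]1CC[C@@H]2[C@@H](OC(=O)[C@]23CC(c2ccccc2)N(c2ccccc2)O3)[C@]2(C)C(=O)C=C[C@@]12O` gives 3.19. The next compound, compound 3 `C[C@H]1CC[C@@H]2[C@@H](OC(=O)[C@]23CC(c2cccc(Cl)c2)N(c2ccccc2)O3)[C@]2(C)C(=O)C=C[C@@]12O`, keeps the shared core and changes a single group: 3-chlorophenyl in place of 2,6-dichlorophenyl on a saturated ring carbon. The 2,6-dichlorophenyl of compound 2 gives way to a 3-chlorophenyl on the same saturated ring carbon of the five-membered ring.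

Among the measured compounds shown here, only one measured step bears on this change, and it is large: a number 1.26 log units higher from compound 1 to compound 2 (beyond the scatter). That step replaced phenyl with 2,6-dichlorophenyl at this same place. The new 3-chlorophenyl matches neither end of that step, so compound 3 is expected to give back part of the rise, perhaps about half. For the measured compounds named here, no measured compound yet carries a 3-chlorophenyl, so this remains a rough reading from two numbers. The expected change is downward, beyond the scatter, and amounts to a number 0.60 log units lower from compound 2 to compound 3 (beyond the scatter). The estimated value for compound 3 is 3.85, with an expected range from 3.45 to 4.25.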

Compound 3, partition coefficient: 3.87
Compound 3: the middle estimate sits 0.02 log units below what was measured; measured number inside the range.
By their numbers in this assay, from the lowest: compound 1; then compound 3; then compound 2.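

In this assay the 3-chlorophenyl group gives a middle point at this saturated ring carbon: there is a number 0.68 log units higher from compound 1 to compound 3 (beyond the scatter) and then a number 0.58 log units lower from compound 2 to compound 3 (beyond the scatter). Both steps lie beyond the scatter, so phenyl, 3-chlorophenyl and 2,6-dichlorophenyl now fall in a clear order at this position, and none of the three compounds goes against it. Compound 2 and compound 3 differ both in how many chlorines the ring carries and in where they sit, so these numbers cannot divide the drop between those two changes, and no measurement at hand explains the order.

The compounds shown leave open whether a 2-chlorophenyl or a 4-chlorophenyl would give a number close to that of compound 3, which would help separate the count of chlorines from their placement. They also leave open how far the number would move with a different kind of group at this carbon, such as a phenyl ring carrying an amine or a carboxylic acid.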